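This account rests on a few compounds, and the source may have more. Where it says the series, first, only, none or still open, it means among the compounds named here.

Of the compounds shown here, three have been tested in an ADME assay on RAW264.7 cells (Mus musculus) for cytotoxicity, read by MTT assay, with a stated time of 48 h, tested at 50 uM; on this read-out higher numbers stand for more inhibition at the one concentration tested (going by the name of the read-out) and lower numbers for less inhibition. Compound 1 `Cc1ccc(C)c(N2C(=N)S/C(=C\c3ccc(OCc4ccccc4)cc3)C2=O)c1` gives 45.8%, compound 2 `NC(=O)c1c(NC(=O)c2ccc(Cl)cc2)sc2c1CCN(C(=O)c1ccccc1)C2` gives 42.5%, and compound 3 `NC(=O)c1c(NC(=O)c2ccc(Oc3ccccc3)cc2)sc2c1CCN(C(=O)c1ccccc1)C2` gives 4.71%. Compound 3 therefore stands lowest of the three, and its distances to both other compounds are beyond the scatter. Among the compounds with values here, the one change measured so far within the shared core of compound 2 and compound 3 is phenoxy in place of chloro on an aromatic carbon, which moved the read-out a number 37.8 percentage points lower from compound 2 to compound 3 (beyond the scatter).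

Compound 4 `NC(=O)c1c(NC(=O)c2ccc(Oc3ccccc3)cc2)sc2c1CCN(Cc1ccccc1)C2` is not yet measured. It differs from compound 3 in one place: benzyl in place of benzoyl on an amine nitrogen in a ring. Within the data shown here, no measured step among the three tested compounds touches this amine nitrogen in a ring, so nothing yet shows how a change there moves the read-out. Among the measured compounds shown here, the only step seen concerns a different part of the shared core and cannot be carried over to this one. For the measured compounds named here, with no bearing step, the expectation for compound 4 is no movement beyond the scatter, so the estimated step is a number 3.3 percentage points higher from compound 3 to compound 4 (within the scatter). On that basis compound 4 is expected to give about 8% in this assay, with a range from -5% to 30%.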

Compound 4, a percentage reported as inhibition, at one concentration (the size of the read-out at that concentration, not a potency): 23.6%
For compound 4 the middle estimate is 15.6 percentage points below the measured one; low and high end bracket the measured number.
By their numbers in this assay, from the lowest: compound 3; then compound 4; then compounds 2 and 1 (each within the scatter of the next).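

At the amine nitrogen in a ring, the read-out of this assay does respond to a change: benzyl in place of benzoyl gives a number 18.9 percentage points higher from compound 3 to compound 4 (beyond the scatter), the first measured sign that this position matters. By the counts for the two groups, the change keeps the six-membered aromatic ring of carbon only but removes the double bond outside aromatic rings and the hydrogen-bond acceptor, which are those of the benzoyl carbonyl, so the comparison amounts to the presence or absence of that carbonyl beside an otherwise similar group. No measurement available here accounts for the higher number, so this one step records what happens at the position without explaining it.

On these data alone, with only benzoyl and benzyl seen on this nitrogen, it remains open how other groups there would behave, such as an acetyl group, a simple methyl group or a longer chain ending in a phenyl ring. As far as these compounds go, it also remains open whether the step would keep its direction and size with chloro instead of phenoxy on the aromatic carbon.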